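Working notes: cyclohexyl in place of 4-methylphenyl

The source may report more compounds than this note shows. Statements on the series, on what has been measured and on what is new or still open speak of the compounds shown alone.

Measured in a functional assay on RAW264.7 cells (Mus musculus) for inhibition, read by Griess assay, with stated times of 1 h and 24 h; on this read-out lower numbers stand for stronger inhibition and higher numbers for weaker inhibition:
compound 1 `CCCCCCOc1ccc(C(O)C2OC(=O)c3c(OC)cc(OC)cc32)cc1`: 5360 nM
compound 2 `COCCCOc1ccc(C(O)C2OC(=O)c3c(OC)cc(OC)cc32)cc1`: 1260 nM
compound 3 `COc1cc(OC)c2c(c1)C(C(O)c1ccc(OCc3ccc(C)cc3)cc1)OC2=O`: 3120 nM

In this assay, compound 3 gives 3120 nM. This lies within the scatter of the number for compound 1, with a 1.7-fold lower number from compound 1 to compound 3 (0.24 log units; within the scatter). Compound 2 has the lowest number of the three, and a 2.5-fold higher number from compound 2 to compound 3 (0.39 log units; beyond the scatter) lies beyond the scatter.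

The next compound is compound 4 `COc1cc(OC)c2c(c1)C(C(O)c1ccc(OCC3CCCCC3)cc1)OC2=O`, which carries cyclohexyl in place of 4-methylphenyl on a saturated chain carbon bound to an oxygen on an aromatic ring.

Going by the values given here, no measured compound carries cyclohexyl, so the evidence is indirect. Exchanges at this place gave a 1.7-fold lower number from compound 1 to compound 3 (0.24 log units; within the scatter) for pentyl to 4-methylphenyl, which is within the scatter. The modest steps, a 4.3-fold lower number from compound 1 to compound 2 (0.63 log units; beyond the scatter) and a 2.5-fold higher number from compound 2 to compound 3 (0.39 log units; beyond the scatter), both involve compound 2 and its 2-methoxyethyl group. Cyclohexyl is carbon only, like the groups exchanged in the step within the scatter, so no step beyond the scatter is expected in this assay. The estimated change is a 1.1-fold higher number from compound 3 to compound 4 (0.05 log units; within the scatter). For compound 4 the estimated value is 3500 nM, with an expected range of 1600 nM to 7500 nM.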

Compound 4, half-maximal inhibitory concentration: > 10000 nM
Compound 4 gave a limit, no number (the forecaster's own chance of this, stated with the estimate: 5%); at least 2.8-fold (0.45 log units) between middle value and limit.
By their numbers in this assay, from the lowest: compound 2; then compounds 3 and 1 (each within the scatter of the next). At a limit, above all of these: compound 4.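

In this assay, compound 4 gives a limit and not a number: the limit of > 10000 nM in this assay, at which 1 of the 4 values shown sits. Cyclohexyl in place of 4-methylphenyl gives an at least 3.2-fold higher number from compound 3 to compound 4 (0.50 log units; beyond the scatter), so exchanging one carbon-only group for another at this place can move the read-out beyond the scatter, which the earlier 1.7-fold lower number from compound 1 to compound 3 (0.24 log units; within the scatter) had not shown. Against 2-methoxyethyl the step is an at least 7.9-fold higher number from compound 2 to compound 4 (0.89 log units; beyond the scatter), while against pentyl it is an at least 1.8-fold higher number from compound 1 to compound 4 (0.27 log units; that floor lies within the scatter), a floor that does not separate the cyclohexyl compound from the pentyl compound.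

As far as these compounds go, how far the value of compound 4 lies past its limit stays open, and with it the full size of these steps. Also open, from the compounds shown here alone, is how an amine, a carboxylic acid or a longer chain ending in methoxy would compare with the 2-methoxyethyl group of compound 2 at this place.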